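Swapping isobutyl for sec-butyl on a shared core

The source may hold more compounds than are shown below. What is called first, only, known or untested is meant among the compounds shown, and "the series" means these compounds.

Measured compounds:
- compound 1, `CCC(C)C(C(=O)Nc1ccc(C(C)=O)cc1)N(C(=O)c1ccccc1)S(=O)(=O)c1ccc([N+](=O)[O-])cc1`, gives 28.6% in a functional assay for inhibition, read by spectrophotometry, with a stated time of 20 min, tested at 1 mg/mL; a lower number here means a weaker effect, a higher number a stronger effect of the compound at the concentration tested
- compound 2, `CC(=O)c1ccc(NC(=O)CN(C(=O)c2ccccc2)S(=O)(=O)c2ccccc2)cc1`, gives 40.5% in this assay
- compound 3, `CC(=O)c1ccc(NC(=O)C(CC(C)C)N(C(=O)c2ccccc2)S(=O)(=O)c2ccccc2)cc1`, gives 27.7% in this assay

Compound 3 has the lowest of the three numbers, though its number and that of compound 1 lie within the scatter of each other, so no order between those two can be claimed. Only compound 2 stands clearly apart: the step of a number 12.8 percentage points lower from compound 2 to compound 3 (beyond the scatter) shows that putting isobutyl onto the chain carbon weakened the effect by a modest amount.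

Compound 4, `CCC(C)C(C(=O)Nc1ccc(C(C)=O)cc1)N(C(=O)c1ccccc1)S(=O)(=O)c1ccccc1`, differs from compound 3 by one change: sec-butyl in place of isobutyl on a saturated chain carbon bound to an amide-type nitrogen and a carbonyl carbon. Among the compounds with values here, compound 1 also carries sec-butyl at this place, yet it differs from compound 3 in a second place as well, so its number alone cannot be read as a step for this change; it shows only that a sec-butyl compound sits at about the same level as compound 3. Within the data shown here, no measured step isolates the isobutyl-to-sec-butyl exchange. Among the measured compounds shown here, the one relevant step, from compound 2 to compound 3, concerns a different group. Compound 4 is therefore expected to stay close to compound 3, with a number 1.3 percentage points higher from compound 3 to compound 4 (within the scatter) as the expected step, not beyond the scatter. The estimate for compound 4 is 29%, ranging from 17% to 41%.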

Compound 4, a percentage reported as inhibition, at one concentration (the size of the read-out at that concentration, not a potency): 9.71%
Beside the measured number, compound 4's estimate is 19.3 percentage points above it, outside the stated range (below it).
By their numbers in this assay, from the lowest: compound 4; then compounds 3 and 1 (each within the scatter of the next); then compound 2.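

Isobutyl and sec-butyl have the same atoms, joined differently, yet in this assay this exchange alone gives a number 18 percentage points lower from compound 3 to compound 4 (beyond the scatter), so at this chain carbon the way the group's atoms are joined matters, and not only whether a group is present there. Measured from the hydrogen of the unsubstituted chain carbon, sec-butyl gives a number 30.8 percentage points lower from compound 2 to compound 4 (beyond the scatter), the largest step shown so far, while isobutyl gives the smaller a number 12.8 percentage points lower from compound 2 to compound 3 (beyond the scatter). With sec-butyl kept in place, hydrogen in place of nitro on an aromatic carbon gives a number 18.9 percentage points lower from compound 1 to compound 4 (beyond the scatter), so the nitro compound, which differs from the isobutyl compound in two places, was no guide to the exchange of isobutyl for sec-butyl.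

No measurement at hand accounts for these steps. From the compounds shown here alone, it remains open where a straight butyl chain, a tert-butyl group or a benzyl group on this chain carbon would fall, and whether exchanging nitro for hydrogen on the aromatic carbon would give a step of similar size with isobutyl on the chain.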